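Chloro for fluoro on the nitrogen-bearing aromatic ring

A few compounds are considered here, and "the series" means these few. Any claim that something is new, unique, unknown or untested is made for them only; others in the source may bear on it.

Of the compounds shown here, two sharing one core have been measured in a functional assay on cells for inhibition of Polyunsaturated fatty acid 5-lipoxygenase (Homo sapiens); on this read-out lower numbers stand for stronger inhibition and higher numbers for weaker inhibition. Compound 1, `CC1CN(c2cccc(Cl)c2)NC(=O)N1`, gives 2700 nM. Compound 2, `CC1CN(c2cccc(F)n2)NC(=O)N1`, gives 6000 nM, the higher of the two numbers shown; the gap to compound 1 lies beyond the usual scatter, though the two structures differ in more than one place, so only the two values themselves can be compared. Compound 3, `CC1CN(c2cccc(Cl)n2)NC(=O)N1`, has not yet been measured. It differs from compound 2 in a single place: chloro in place of fluoro on an aromatic carbon. For the measured compounds named here, no step between two measured compounds isolates this change, so any expectation rests on compound 2 alone and on the size of change a single halogen swap usually brings. The step is expected to be modest, towards a lower number, and may well stay within the scatter, so that for compound 3 a value of 3500 nM is estimated, within 1500 nM to 8000 nM, meaning an expected step of a 1.7-fold lower number from compound 2 to compound 3 (0.23 log units; within the scatter).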

Compound 3, half-maximal inhibitory concentration: 1600 nM
Compound 3: the middle estimate sits 2.2-fold (0.34 log units) above what was measured, within the range that was stated.
By their numbers in this assay, from the lowest: compounds 3 and 1 (each within the scatter of the next); then compound 2.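

In this assay, for the compounds shown here, the halogen on the aromatic carbon next to the ring nitrogen proves to matter: chloro in place of fluoro gives a 3.8-fold lower number from compound 2 to compound 3 (0.57 log units; beyond the scatter), the first step here that isolates a single change. With chloro on both rings, compound 1 at 2700 nM and compound 3 at 1600 nM lie within the scatter of each other, so this pair shows no difference that can be told apart between the ring without the nitrogen and the ring with it. Nothing measured on these compounds accounts for the step.

As far as these compounds go, how bromo, a methyl group or an amine on this same carbon would read remains open. Also open, from the compounds shown here alone, is whether chloro in place of fluoro brings a step of similar size on the ring of compound 1.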